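The compounds below may be only part of what the source reports. "The series", "measured", "known", "first", "only" and "open" are said of these compounds alone.

Measured so far in an assay on HL-60 cells for agonist activity at vitamin D3 receptor (Homo sapiens), read by microscopy, with a stated time of 96 h; a higher number here means that more compound is needed for the effect, a lower number that less compound is needed:
compound 1 `CCn1c(C(=O)N(C)CCC#N)ccc1C(CC)(CC)c1ccc(OCC(=O)C(C)(C)C)c(C)c1` gives 9800 nM
compound 2 `CCOC(=O)CN(C)C(=O)c1ccc(C(CC)(CC)c2ccc(OCC(O)C(C)(C)C)c(C)c2)n1CC` gives 210 nM
compound 3 `CCN(CC)CCCNC(=O)c1ccc(C(CC)(CC)c2ccc(OCC(O)C(C)(C)C)c(C)c2)n1CC` gives 66 nM

Compound 3 stands lowest of the three; compound 2 is nearest, and compound 1 the furthest, with a large gap. Going by the values given here, the only step that touches the amide part is a 3.2-fold lower number from compound 2 to compound 3 (0.50 log units; beyond the scatter), a modest move to a lower number when the amine-bearing chain replaces the ester-bearing one. Compound 4 `CCn1c(C(=O)N(C)CCC#N)ccc1C(CC)(CC)c1ccc(OCC(O)C(C)(C)C)c(C)c1` carries the hydroxyl chain of compounds 2 and 3 and differs from compound 3 by (2-cyanoethyl)(methyl)amino in place of (3-(diethylamino)propyl)amino on a carbonyl carbon. Among the compounds with values here, compound 1, which bears the same amide group as compound 4 but a ketone in the ether chain, gives a high number; no step connects it to compound 4. From the modest size of the amide step a 3.2-fold lower number from compound 2 to compound 3 (0.50 log units; beyond the scatter), compound 4 is expected to sit near compound 2, a step of a 4.5-fold higher number from compound 3 to compound 4 (0.66 log units; beyond the scatter) to a higher number, estimated at 300 nM (range 60 nM to 1500 nM).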

Compound 4, half-maximal effective concentration: 1960 nM
Compound 4: middle estimate off by 6.5-fold (0.82 log units), on the low side; the measured number lies above the stated range.
By their numbers in this assay, from the lowest: compound 3; then compound 2; then compound 4; then compound 1.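

The group on the carbonyl carbon matters more than the earlier step showed: there is a 30-fold higher number from compound 3 to compound 4 (1.47 log units; beyond the scatter) on entry of (2-cyanoethyl)(methyl)amino, and also a 9.3-fold higher number from compound 2 to compound 4 (0.97 log units; beyond the scatter) for the same amide group. With that amide held fixed, the ether chain counts too, as 1-hydroxy-2,2-dimethylpropyl in place of (tert-butyl)carbonyl gives a 5.0-fold lower number from compound 1 to compound 4 (0.70 log units; beyond the scatter) in this series. No available evidence accounts for the size of these steps.

Going by these compounds, whether the low number of compound 3 rests on the diethylamino end, the amide hydrogen or the chain length stays open, as these change together. A shorter chain ending in dimethylamino or a piperidine on the same amide would begin to separate them.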